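Methylpiperazinyl for dimethylamino on compound 3

A few compounds are considered here, and "the series" means these few. Any claim that something is new, unique, unknown or untested is made for them only; others in the source may bear on it.

In an assay on Sf21 cells for inhibition of high affinity nerve growth factor receptor (Homo sapiens), read by HTRF, with a stated time of 30 min, in the presence of a further agent that is not named here (a lower number here means a stronger inhibitor, a higher number a weaker inhibitor), compound 3 `CN(C)c1cccc(C(=O)Nc2n[nH]c3c2CN(Cc2cc(F)cc(F)c2)C3(C)C)c1` gives 270 nM, the second highest of the three numbers measured; compound 1 `CC1(C)c2[nH]nc(NC(=O)c3ccc4ncccc4c3)c2CN1Cc1cc(F)cc(F)c1` gives 180 nM and compound 2 `CC1(C)c2[nH]nc(NC(=O)c3ccc(F)cc3)c2CN1Cc1cc(F)cc(F)c1` gives 350 nM. The measured steps all lie within the scatter: a 1.5-fold higher number from compound 1 to compound 3 (0.18 log units; within the scatter), a 1.3-fold lower number from compound 2 to compound 3 (0.11 log units; within the scatter) and a 1.9-fold higher number from compound 1 to compound 2 (0.29 log units; within the scatter). Compound 4 `CN1CCN(c2cccc(C(=O)Nc3n[nH]c4c3CN(Cc3cc(F)cc(F)c3)C4(C)C)c2)CC1` differs from compound 3 by 4-methylpiperazin-1-yl in place of dimethylamino on an aromatic carbon. Among the compounds with values here, no measured step tests this change, and the three measured variations of the group on the carbonyl carbon moved nothing beyond the scatter, so in this assay no step beyond the scatter is expected in either direction. Compound 4 is therefore estimated at 300 nM, with a range from 120 nM to 750 nM. That estimate means an expected step of a 1.1-fold higher number from compound 3 to compound 4 (0.05 log units; within the scatter).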

Compound 4, half-maximal inhibitory concentration: 150 nM
Beside the measured number, compound 4's estimate is 2.0-fold (0.30 log units) above it; measured number inside the range.
By their numbers in this assay, from the lowest: compounds 4, 1, 3 and 2 (each within the scatter of the next, the first and the last beyond it).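

In this assay, 4-methylpiperazin-1-yl in place of dimethylamino, on an aromatic carbon meta to a large group, gives a step within the scatter (a 1.8-fold lower number from compound 3 to compound 4 (0.26 log units; within the scatter)). The earlier compounds shown here varied the whole group on the carbonyl carbon; this result shows that at this one position a six-membered non-aromatic ring can replace the open dimethylamino without a step beyond the scatter. Nothing measured here accounts for the result. The compounds shown leave open whether morpholine or piperazine lacking the methyl would behave alike at this position.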